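The source may report more compounds than this note shows. Statements on the series, on what has been measured and on what is new or still open speak of the compounds shown alone.

Compound 2 `Nc1cc(N)c2nc(-c3ccccc3)c(NCc3ccc(F)cc3)nc2c1` is one of two compounds tested in a functional assay on A549 cells (Homo sapiens) for inhibition, read by sulforhodamine B assay, with a stated time of 48 h (on this read-out lower numbers stand for stronger inhibition of growth and higher numbers for weaker inhibition of growth), where compound 2 gives 17800 nM. Its companion, compound 1 `COc1ccc(CNc2nc3cc(N)cc(N)c3nc2-c2ccccc2)cc1OC`, gives 20900 nM in this assay. Going by the values given here, the single measured step, a 1.2-fold lower number from compound 1 to compound 2 (0.07 log units; within the scatter), is within the scatter, so the two numbers cannot be told apart; compound 2 simply sits beside compound 1.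

Compound 3 `Nc1cc(N)c2nc(-c3ccccc3)c(Oc3ccc(F)cc3)nc2c1` differs from compound 2 by 4-fluorophenoxy in place of (4-fluorobenzyl)amino on an aromatic carbon. Among the compounds with values here, no measured step touches this kind of change: the one step known swaps the aryl group at the end of the chain, not the linking atom itself, so it bears on compound 3 only by showing that this part of the molecule tolerated a swap without a shift beyond the scatter. A step of similar size is therefore expected for compound 3, that is, a 1.2-fold higher number from compound 2 to compound 3 (0.09 log units; within the scatter). The estimate for compound 3 in this assay is 22000 nM, with a range from 7000 nM to 70000 nM.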

Compound 3, concentration for 50% growth inhibition: 24000 nM
Estimate against measurement, compound 3: 1.1-fold (0.04 log units) below; the measured number falls inside the stated range.
By their numbers in this assay, from the lowest: compounds 2, 1 and 3 (each within the scatter of the next).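

Replacing the linking atoms themselves, and not only the aryl group at the end of the chain, gives a step that stays within the scatter in this assay: a 1.3-fold higher number from compound 2 to compound 3 (0.13 log units; within the scatter). The swap of (4-fluorobenzyl)amino for 4-fluorophenoxy removes the hydrogen-bond donor of the linker, yet compound 2 and compound 3 cannot be told apart, so the number does not depend on that donor in this pair. Nothing at hand offers an explanation for this result.

On these data alone, all three compounds carry a fluorinated or methoxylated aryl group at this aromatic carbon, so it remains open whether any group here can move the number beyond the scatter. A morpholine, a carboxylic acid or a longer chain at this carbon would test that.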